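A few compounds are considered here, and "the series" means these few. Any claim that something is new, unique, unknown or untested is made for them only; others in the source may bear on it.

Measured in a functional assay on HCT-116 cells (Homo sapiens) for antiproliferative activity, read by MTT assay, with a stated time of 72 h (a higher number here means a weaker inhibitor, a lower number a stronger inhibitor), so far:
Compound 1 `O=C(Nc1ccc(Nc2nccc(NC3CCCC3)n2)cc1)Nc1ccc(Cl)c(C(F)(F)F)c1` gives 2510 nM
Compound 2 `O=C(Nc1ccc(Nc2nccc(Nc3ccccc3Cl)n2)cc1)Nc1ccc(Cl)c(C(F)(F)F)c1` gives 8100 nM
Compound 3 `O=C(Nc1ccc(Nc2nccc(Nc3ccc(Cl)cc3)n2)cc1)Nc1ccc(Cl)c(C(F)(F)F)c1` gives 4660 nM

Compound 3 stands within the scatter of both other compounds, as a 1.9-fold higher number from compound 1 to compound 3 (0.27 log units; within the scatter) and a 1.7-fold lower number from compound 2 to compound 3 (0.24 log units; within the scatter) show. Compound 4 `Cn1cc(Nc2ccnc(Nc3ccc(NC(=O)Nc4ccc(Cl)c(C(F)(F)F)c4)cc3)n2)cn1` differs from it thus: 1-methyl-1H-pyrazol-4-yl in place of 4-chlorophenyl on a nitrogen on an aromatic ring and so 1-methyl-1H-pyrazol-4-yl replaces 4-chlorophenyl on a nitrogen on an aromatic ring. All measured steps fall at this place. Only a 3.2-fold higher number from compound 1 to compound 2 (0.51 log units; beyond the scatter) goes beyond the scatter, and it is modest. No five-membered aromatic ring has been measured there. No step beyond the scatter is therefore expected in this assay and the expected step is a 1.2-fold lower number from compound 3 to compound 4 (0.07 log units; within the scatter) in this estimate. For compound 4 the estimate is 4000 nM with an expected range from 1500 nM to 11000 nM in this account.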

Compound 4, half-maximal inhibitory concentration: 4850 nM
Beside the measured number, compound 4's estimate is 1.2-fold (0.08 log units) below it, within the range that was stated.
By their numbers in this assay, from the lowest: compounds 1, 3, 4 and 2 (each within the scatter of the next, the first and the last beyond it).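

In this assay, the five-membered aromatic ring 1-methyl-1H-pyrazol-4-yl falls within the scatter of all three earlier groups at this nitrogen (a 1.0-fold higher number from compound 3 to compound 4 (0.02 log units; within the scatter); a 1.7-fold lower number from compound 2 to compound 4 (0.22 log units; within the scatter); a 1.9-fold higher number from compound 1 to compound 4 (0.29 log units; within the scatter)). Within the data shown here, replacing 4-chlorophenyl with a ring carrying hetero atoms and hydrogen-bond acceptors therefore gives no readable change, and compounds 1 and 2 remain the only pair separated beyond the scatter. No measurement here explains this result. From the compounds shown here alone, whether an amine or a carboxylic acid on this nitrogen would move the number stays open.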